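The source may report more compounds than this note shows. Statements on the series, on what has been measured and on what is new or still open speak of the compounds shown alone.

The shared core appears in compound 1 `CC(C)c1c(C(=O)NCC2CCCCC2)nn(-c2ccc(F)cc2)c1OC[C@@H](O)C[C@@H](O)CC(=O)O`, compound 2 `CC(C)c1c(C(=O)N2CCCC2c2ccccc2)nn(-c2ccc(F)cc2)c1OC[C@@H](O)C[C@@H](O)CC(=O)O` and compound 3 `CC(C)c1c(C(=O)NCc2ccccn2)nn(-c2ccc(F)cc2)c1OC[C@@H](O)C[C@@H](O)CC(=O)O`. In a functional assay on L6 cells (Rattus norvegicus) for inhibition (a higher number here means a weaker inhibitor, a lower number a stronger inhibitor), compound 1 gives "not determined" (no result reported) and compound 3 gives "not determined" (no result reported), so neither adds a number. In this assay, going by the values given here, compound 2 gives 4340 nM, the only value available, and on that number alone it is a weak inhibitor. Compound 4 `CC(C)c1c(C(=O)N(C)Cc2ccc(F)cc2)nn(-c2ccc(F)cc2)c1OC[C@@H](O)C[C@@H](O)CC(=O)O` is next to be measured in this assay. The change from compound 2 to compound 4 is (4-fluorobenzyl)(methyl)amino in place of 2-phenylpyrrolidin-1-yl on a carbonyl carbon. Among the compounds with values here, no step between two measured compounds is available, so the size can only be guessed: the step from compound 2 to compound 4 is expected to stay within the scatter, in either direction, a 1.1-fold lower number from compound 2 to compound 4 (0.06 log units; within the scatter). For compound 4 in this assay the estimate is 3800 nM, within 1300 nM to 12000 nM.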

Compound 4, half-maximal inhibitory concentration: 2800 nM
The estimate for compound 4 lay 1.4-fold (0.13 log units) above the measured number, within the range that was stated.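

On the carbonyl carbon, (4-fluorobenzyl)(methyl)amino in place of 2-phenylpyrrolidin-1-yl gives a 1.6-fold lower number from compound 2 to compound 4 (0.19 log units; within the scatter) in this assay, the first step readable at this position. Losing the five-membered non-aromatic ring and gaining a fluorine together leave the read-out within the scatter, and this single step cannot separate the two. Nothing at hand explains the result.

Steps to compound 1 and compound 3 cannot be read. As far as these compounds go, whether a morpholine on this carbonyl carbon would move the number beyond the scatter remains open.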